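A few compounds are considered here, and "the series" means these few. Any claim that something is new, unique, unknown or untested is made for them only; others in the source may bear on it.

Measured in a physicochemical assay for lipophilicity, at pH 7.4; on this read-out higher numbers stand for higher lipophilicity and lower numbers for lower lipophilicity:
- Compound 1 `CC(C)Oc1ccc(-c2nnc(-n3cncn3)s2)cc1Cl`: 6.18
- Compound 2 `Cc1c2c(nn1-c1nnc(-c3ccc(OC(C)C)c(C#N)c3)s1)CCN(CCC(=O)O)C2`: 2.76
- Compound 3 `Cc1c(-c2noc(-c3ccc(OC(C)C)c(C#N)c3)n2)ccc2c1CCN(CCC(=O)O)C2`: 3.41

Compound 1 stands highest of the three in this assay, and both other compounds lie below it by more than the usual scatter. The next step leads to compound 4 `CC(C)Oc1ccc(-c2nnc(-c3cn[nH]c3)s2)cc1Cl`, which carries 1H-pyrazol-4-yl in place of 1H-1,2,4-triazol-1-yl on an aromatic carbon. Going by the values given here, no measured pair differs in a single place, so the data offer no direct guide to this change. The expected step is a modest fall, a number 0.38 log units lower from compound 1 to compound 4 (beyond the scatter), only slightly beyond the scatter. For compound 4 the estimated value is 5.8, with an expected range from 5.2 to 6.4.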

Compound 4, distribution coefficient: 5
Estimate against measurement, compound 4: 0.80 log units above; the whole stated range lies above it.
By their numbers in this assay, from the lowest: compound 2; then compound 3; then compound 4; then compound 1.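

In this assay, 1H-pyrazol-4-yl in place of 1H-1,2,4-triazol-1-yl, on an aromatic carbon of the five-membered aromatic ring with 2 nitrogen and 1 sulfur, gives a large step (a number 1.18 log units lower from compound 1 to compound 4 (beyond the scatter)). Going by these compounds alone, this is the first change in a single place, and it shows that the read-out responds strongly here even when the entering and leaving groups have equal heavy-atom counts. No measurement shown accounts for the step. The compounds shown leave open whether the hydrogen-bond donor of 1H-pyrazol-4-yl or its ring carbon tracks the step, and how a primary amide or a hydroxymethyl group would read at this position.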